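Swapping the Amide Substituent for a Dimethylaminopropyl Chain

This account rests on a few compounds, and the source may have more. Where it says the series, first, only, none or still open, it means among the compounds named here.

Three compounds share one core and differ only in the group on the amide-type nitrogen. Compound 1 `O=C(N[C@@H]1CCNC1)c1cc(-c2ccc(NS(=O)(=O)c3cccc(Cl)c3Cl)cc2)nc2[nH]ncc12` carries pyrrolidin-3-yl; in an assay for inhibition of serine/threonine-protein kinase Sgk1 (Homo sapiens), with stated times of 30 min and 60 min, in the presence of a further agent that is not named here (a higher number here means a weaker inhibitor, a lower number a stronger inhibitor), compound 1 gives < 1 nM, which is a limit of the assay rather than a number (the limit of < 1 nM in this assay, at which 1 of the 3 values shown sits). Compound 2 `O=C(NC1CCN(C2CC2)C1)c1cc(-c2ccc(NS(=O)(=O)c3cccc(Cl)c3Cl)cc2)nc2[nH]ncc12` carries 1-cyclopropylpyrrolidin-3-yl, and in this assay compound 2 gives 610 nM. Compound 3 `CC(C)NC(=O)c1cc(-c2ccc(NS(=O)(=O)c3cccc(Cl)c3Cl)cc2)nc2[nH]ncc12` carries isopropyl, and in this assay compound 3 gives 17600 nM. Compound 2 thus holds the lower of the two numbers, with a 29-fold higher number from compound 2 to compound 3 (1.46 log units; beyond the scatter); the steps of an at least 610-fold higher number from compound 1 to compound 2 (2.78 log units; beyond the scatter) and an at least 17000-fold higher number from compound 1 to compound 3 (4.24 log units; beyond the scatter) were both large as well. Compound 4 `CN(C)CCCNC(=O)c1cc(-c2ccc(NS(=O)(=O)c3cccc(Cl)c3Cl)cc2)nc2[nH]ncc12` differs from compound 2 by 3-(dimethylamino)propyl in place of 1-cyclopropylpyrrolidin-3-yl on an amide-type nitrogen. Both the leaving and the entering group count no hydrogen-bond donor and one hydrogen-bond acceptor, whereas every measured step changed that count or removed a ring altogether, so the measured steps give only a loose guide. Compound 4 is expected to stay near compound 2, with a step of a 1.5-fold lower number from compound 2 to compound 4 (0.18 log units; within the scatter). Compound 4 is estimated at 400 nM, within 60 nM to 2500 nM.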

Compound 4, half-maximal inhibitory concentration: 633 nM
The estimate for compound 4 lay 1.6-fold (0.20 log units) below the measured number; low and high end bracket the measured number.
By their numbers in this assay, from the lowest: compounds 2 and 4 (each within the scatter of the next); then compound 3. At a limit, below all of these: compound 1.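

The step of a 1.0-fold higher number from compound 2 to compound 4 (0.02 log units; within the scatter) shows that, on this amide-type nitrogen, 3-(dimethylamino)propyl can take the place of 1-cyclopropylpyrrolidin-3-yl, with both of its rings gone, without a change beyond the scatter. Neither isopropyl nor 3-(dimethylamino)propyl has a ring, yet the record shows a 28-fold lower number from compound 3 to compound 4 (1.44 log units; beyond the scatter), so the presence of a ring alone does not track these numbers. The gap to pyrrolidin-3-yl remains wide, an at least 630-fold higher number from compound 1 to compound 4 (2.80 log units; beyond the scatter), and that step starts from a limit of the assay rather than a number: the limit of < 1 nM in this assay, at which 1 of the 4 values shown sits.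

The compounds shown leave open whether 3-aminopropyl, with a primary amine at the chain end, would read closer to compound 1 or to compound 4. They also leave open how a shorter or longer chain ending in dimethylamino would compare.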